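One Group Exchanged: From Compound 2 to Compound 4

A few compounds are considered here, and "the series" means these few. Any claim that something is new, unique, unknown or untested is made for them only; others in the source may bear on it.

Of the compounds shown here, three sharing one core have been tested in an assay on mitochondria from L6 cells (Rattus norvegicus) for activation, with a stated time of 90 min; a lower number here means that less compound is needed, a higher number that more compound is needed for the effect. Compound 1 `Oc1nc2nonc2nc1Nc1ccc(OC(F)(F)F)cc1Cl` gives 1400 nM, and compound 2 `Oc1nc2nonc2nc1Nc1ccc(SC(F)(F)F)cc1` gives 1400 nM; these two are level within the scatter and together are the lowest of the three numbers. Compound 3 `Oc1nc2nonc2nc1Nc1cccc2ccccc12` gives 20400 nM, a clearly higher number than compound 2, beyond the scatter. Compound 4 `CC(=O)c1ccc(Nc2nc3nonc3nc2O)cc1` is not yet measured and differs from compound 2 in a single place: acetyl in place of (trifluoromethyl)sulfanyl on an aromatic carbon. Among the compounds with values here, no measured pair shows this exchange, so its effect is unknown. Within the data shown here, the expected step of a 2.5-fold higher number from compound 2 to compound 4 (0.40 log units; beyond the scatter) is modest, toward a higher number, since the only anchor is compound 2 at 1400 nM. For compound 4 the estimated value is 3500 nM, with a range from 1200 nM to 12000 nM.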

Compound 4, half-maximal effective concentration: 93700 nM
Compound 4: middle estimate off by 27-fold (1.43 log units), on the low side; measured number outside the range, above it.
By their numbers in this assay, from the lowest: compounds 1 and 2 (each within the scatter of the next); then compound 3; then compound 4.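

At this position, para to a large group, the exchange matters greatly: acetyl in place of (trifluoromethyl)sulfanyl brings a 67-fold higher number from compound 2 to compound 4 (1.83 log units; beyond the scatter). Within the data shown here, the earlier compounds offered no step that changed only one place, so this is the first direct view of what a single group on this aromatic carbon can do. Nothing measured here explains the size of this step.

Going by these compounds, whether an amine, a methoxy group or a carboxylic acid at this position would stay closer to compound 2 remains open. So does whether acetyl would give a similar step on another aromatic carbon of this ring.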